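Thiophen-2-yl in place of furan-2-yl on compound 3

This account rests on a few compounds, and the source may have more. Where it says the series, first, only, none or still open, it means among the compounds named here.

Measured in a functional assay on K562 cells (Homo sapiens), read by MTT assay, with a stated time of 72 h; on this read-out lower numbers stand for stronger inhibition and higher numbers for weaker inhibition:
- compound 1 `C#Cc1cn([C@@H]2O[C@H](CO)[C@@H](O)[C@H]2O)c2ncnc(SC)c12`: 30 nM
- compound 2 `CNc1ncnc2c1c(-c1ccco1)cn2[C@@H]1O[C@H](CO)[C@@H](O)[C@H]1O`: 220 nM
- compound 3 `Nc1nc(N)c2c(-c3ccco3)cn([C@@H]3O[C@H](CO)[C@@H](O)[C@H]3O)c2n1`: > 20000 nM (a limit of the assay)

Compound 1 gives 30 nM and compound 2 gives 220 nM, and both are true numbers. Compound 3 stands apart from them, since its > 20000 nM is a limit and not a number. That makes it the one case of the limit of > 20000 nM in this assay, at which 1 of the 3 values shown sits.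

The next compound, compound 4 `Nc1nc(N)c2c(-c3cccs3)cn([C@@H]3O[C@H](CO)[C@@H](O)[C@H]3O)c2n1`, keeps the core of compound 3 and exchanges one group: thiophen-2-yl in place of furan-2-yl on an aromatic carbon. The thiophen-2-yl sits in the same place, on an aromatic carbon.

Among the compounds with values here, no measured pair in this set shows the exchange, so the expectation starts from compound 3 alone, whose > 20000 nM is only a limit. The expected step is small, an at least 1.3-fold lower number from compound 3 to compound 4 (0.12 log units; that floor lies within the scatter), and no large gain in this assay is anticipated. A report of a limit alone is quite likely here as well. For compound 4 the estimated value is 15000 nM, with an expected range from 4000 nM to 30000 nM.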

Compound 4, half-maximal inhibitory concentration: > 20000 nM
Compound 4 ended at the assay's limit (the forecaster's own chance of this, stated with the estimate: 60%); middle value at least 1.3-fold (0.12 log units) away from the limit.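

Compound 3 and compound 4 both end at a limit and not a number, so no step can be read for thiophen-2-yl in place of furan-2-yl: the limit of > 20000 nM in this assay, at which 2 of the 4 values shown sit. The compounds shown leave open whether this exchange changes the read-out on the shared core at all.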